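Shrinking the substituent: from cyclohexyl to methyl

The source may hold more compounds than are shown below. What is called first, only, known or untested is meant among the compounds shown, and "the series" means these compounds.

Measured so far:
compound 1 `CC(C)(C)c1cc(N)c2cc(NC(=O)/C=C/c3ccc(C(F)(F)F)cc3)ccc2n1` 29 nM
compound 2 `Nc1cc(C2CCCC2)nc2ccc(NC(=O)/C=C/c3ccc(C(F)(F)F)cc3)cc12` 68 nM
compound 3 `Nc1cc(C2CCCCC2)nc2ccc(NC(=O)/C=C/c3ccc(C(F)(F)F)cc3)cc12` 96 nM

Of the compounds shown here, three sharing one core have been tested in a functional assay on HEK293 cells for activation of melanin-concentrating hormone receptor 1 (Homo sapiens), read by inositol phosphate accumulation; on this read-out higher numbers stand for an effect only at larger amounts of compound and lower numbers for an effect already at smaller amounts. Compound 1 gives 29 nM, compound 2 gives 68 nM, and compound 3 gives 96 nM. Compound 3 thus has the highest of the three numbers; it lies beyond the scatter from compound 1, with a 3.3-fold higher number from compound 1 to compound 3 (0.52 log units; beyond the scatter), but within the scatter of compound 2, with a 1.4-fold higher number from compound 2 to compound 3 (0.15 log units; within the scatter), so the two cannot be ranked against each other.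

Compound 4 `Cc1cc(N)c2cc(NC(=O)/C=C/c3ccc(C(F)(F)F)cc3)ccc2n1` is not yet measured. It differs from compound 3 by methyl in place of cyclohexyl on an aromatic carbon. Going by the values given here, no measured step replaces a ring with a methyl, but the steps that alter this same position bear on it: a 2.3-fold higher number from compound 1 to compound 2 (0.37 log units; beyond the scatter) and a 3.3-fold higher number from compound 1 to compound 3 (0.52 log units; beyond the scatter) show that the smaller, branched tert-butyl gave lower numbers than either ring, while a 1.4-fold higher number from compound 2 to compound 3 (0.15 log units; within the scatter) shows little between the two rings. A smaller group is therefore expected to move the number down rather than up, though a methyl is far smaller than anything measured, so the size is uncertain. Compound 4 is estimated to show a 1.6-fold lower number from compound 3 to compound 4 (0.20 log units; within the scatter) in this assay, giving an expected value of 60 nM with a range from 15 nM to 250 nM.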

Compound 4, half-maximal effective concentration: 140 nM
The estimate for compound 4 lay 2.3-fold (0.37 log units) below the measured number, within the range that was stated.
By their numbers in this assay, from the lowest: compound 1; then compounds 2, 3 and 4 (each within the scatter of the next, the first and the last beyond it).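

In this assay, replacing cyclohexyl with the far smaller methyl leaves the number within the scatter (a 1.5-fold higher number from compound 3 to compound 4 (0.16 log units; within the scatter)), yet compound 4 separates from the other two compounds, modestly but beyond the scatter (a 2.1-fold higher number from compound 2 to compound 4 (0.31 log units; beyond the scatter); a 4.8-fold higher number from compound 1 to compound 4 (0.68 log units; beyond the scatter)). The number therefore does not fall steadily as this substituent shrinks: cyclohexyl and methyl, the largest and smallest groups here, cannot be ranked against each other, while compound 1, with tert-butyl, has the lowest number of the four, beyond the scatter of each of the others. No measurement at hand explains why tert-butyl stands apart from the rings and the methyl.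

The compounds shown leave open whether the advantage of tert-butyl depends on its branching, which isopropyl or a cyclopropyl ring at the same carbon would help to separate from overall size. They also leave open how a phenyl ring, a methoxy group or an amine on this aromatic carbon would compare with the carbon-only groups seen so far.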